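Adding Chlorine to the Weakest Vasopressin Binder

This account rests on a few compounds, and the source may have more. Where it says the series, first, only, none or still open, it means among the compounds named here.

Compound 3 `O=C(c1ccc(N2CCCC2)cc1)N1CCCCc2ccccc21` is the weakest binder of the three measured compounds: in an assay on HeLa cells for binding affinity to Vasopressin V2 receptor (Homo sapiens) (a higher number here means a weaker inhibitor, a lower number a stronger inhibitor), compound 3 gives 1000 nM, while compound 1 `CNc1ccc(C(=O)N2CCCCc3ccccc32)c(Cl)c1` gives 35 nM and compound 2 `CCCCNc1ccc(C(=O)N2CCCCc3ccccc32)c(Cl)c1` gives 22 nM. Compound 4 `O=C(c1ccc(N2CCCC2)cc1Cl)N1CCCCc2ccccc21` differs from compound 3 by chloro in place of hydrogen on an aromatic carbon. For the measured compounds named here, no measured step tests this change directly; the only measured step, a 1.6-fold lower number from compound 1 to compound 2 (0.20 log units; within the scatter), alters the amine substituent instead. Compounds 1 and 2 both carry the chloro group that compound 3 lacks, and both bind far more tightly than compound 3, so compound 4 is expected to move toward them, with an estimated step of a 17-fold lower number from compound 3 to compound 4 (1.22 log units; beyond the scatter). Compound 4 is therefore estimated at 60 nM, within a range from 15 nM to 250 nM.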

Compound 4, half-maximal inhibitory concentration: 9 nM
Estimate against measurement, compound 4: 6.7-fold (0.82 log units) above; measured number outside the range, below it.
By their numbers in this assay, from the lowest: compound 4; then compounds 2 and 1 (each within the scatter of the next); then compound 3.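

In this assay chloro in place of hydrogen on this aromatic carbon gives a 110-fold lower number from compound 3 to compound 4 (2.05 log units; beyond the scatter) and so, on its own, turns a poor binder into a strong one. With chloro kept, pyrrolidin-1-yl in place of butylamino gives a 2.4-fold lower number from compound 2 to compound 4 (0.39 log units; beyond the scatter) and pyrrolidin-1-yl in place of methylamino gives a 3.9-fold lower number from compound 1 to compound 4 (0.59 log units; beyond the scatter) so neither open-chain amine matches pyrrolidin-1-yl here.

From the compounds shown here alone, whether fluoro, bromo or methyl on the same carbon would serve as well stays open, as does the size of the chloro step alongside butylamino or methylamino. Nothing shown gives a measured reason for these steps.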